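Diacyl isothiourea pair; selenium benzyl analogue still to measure

A few compounds are considered here, and "the series" means these few. Any claim that something is new, unique, unknown or untested is made for them only; others in the source may bear on it.

Measured so far in a functional assay on K562 cells (Homo sapiens) for cytotoxicity, read by MTT assay, with a stated time of 72 h; a lower number here means that less compound is tolerated, a higher number that more compound is tolerated:
compound 1, `CS/C(=N\C(=O)c1sccc1Cl)NC(=O)c1sccc1Cl`: > 100000 nM
compound 2, `CS/C(=N\C(=O)c1csc([N+](=O)[O-])c1)NC(=O)c1csc([N+](=O)[O-])c1`: > 100000 nM

Compound 1 `CS/C(=N\C(=O)c1sccc1Cl)NC(=O)c1sccc1Cl` returns in this assay only > 100000 nM, which is a limit of the assay and not a number. Compound 2 `CS/C(=N\C(=O)c1csc([N+](=O)[O-])c1)NC(=O)c1csc([N+](=O)[O-])c1` returns in this assay only > 100000 nM, again a limit rather than a number. For the measured compounds named here, compound 2 therefore stands at the limit of > 100000 nM in this assay, at which 2 of the 2 values shown sit, and no compound in the set has yet given a numerical read-out. Going by the values given here, with both values at the limit, no step between measured compounds can be sized, and nothing in the pair says whether the core tolerates change at the carbon with a double bond to nitrogen.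

Compound 3 `O=C(/N=C(/NC(=O)c1csc([N+](=O)[O-])c1)[Se]Cc1ccccc1)c1csc([N+](=O)[O-])c1` is compound 2 with a group of 8 heavy atoms (7 carbon, 1 selenium; one six-membered aromatic ring of carbon only) in place of a group of 2 heavy atoms (1 carbon, 1 sulfur; no ring), on a carbon with a double bond to nitrogen. The expected step of an at least 1.2-fold lower number from compound 2 to compound 3 (0.09 log units; that floor lies within the scatter) is toward less compound tolerated, but small and uncertain, and a limit read-out remains likely. Compound 3 is estimated at 80000 nM, within 20000 nM to 300000 nM.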

Compound 3, concentration lethal to 50% of the cells: 88200 nM
Compound 3: middle estimate off by 1.1-fold (0.04 log units), on the low side; the measured number falls inside the stated range.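

In this assay, for the compounds shown here, compound 3 gives the only numerical read-out of the set, 88200 nM, so with this group in place of methylsulfanyl on the carbon with a double bond to nitrogen, the series yields a number for the first time. The change reads as an at least 1.1-fold lower number from compound 2 to compound 3 (0.05 log units; that floor lies within the scatter), and this floor alone establishes no real shift in tolerated compound. The true size of the step stays unfixed because compound 2 returns only a limit of the assay: the limit of > 100000 nM in this assay, at which 2 of the 3 values shown sit.

Selenium and the benzyl part enter together in this one step, so their contributions remain unseparated; a benzylsulfanyl group or a methylselanyl group on the same carbon would pull them apart. Also open, as far as these compounds go, is whether an amine or a longer alkyl chain at this place would give a number at all, and whether the acyl groups of compound 1 would respond to the same change as those of compound 2 do.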